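Chloro substitution on the shared core in a cytotoxicity series

The source may report more compounds than this note shows. Statements on the series, on what has been measured and on what is new or still open speak of the compounds shown alone.

Compound 1 `ClCc1ccccc1Cn1cnc2c(Cl)nc(Cl)nc21` and compound 2 `ClCc1ccccc1Cn1cnc2c(Cl)ncnc21` share one core; compound 3 `ClCc1cccc(Cn2cnc3c(Cl)ncnc32)c1` and the still unmeasured compound 4 `ClCc1cccc(Cn2cnc3c(Cl)nc(Cl)nc32)c1` share another. The difference between the two cores is not broken down here. In a functional assay on SF-268 cells (Homo sapiens) for cytotoxicity, read by sulforhodamine B assay, with a stated time of 48 h (a higher number here means a weaker inhibitor of growth, a lower number a stronger inhibitor of growth), compound 1 gives 4160 nM, compound 2 gives 10900 nM and compound 3 gives 15500 nM. Compound 3 stands within the scatter of compound 2, while its gap to compound 1 lies beyond the scatter.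

Going by the values given here, the one counted step in this assay is a 2.6-fold lower number from compound 2 to compound 1 (0.42 log units; beyond the scatter), brought about by chloro in place of hydrogen on an aromatic carbon. Among the compounds with values here, the same change, (chloro in place of hydrogen on an aromatic carbon), carries compound 3 to compound 4; the two cases agree in every detail of the surroundings, so they count as the same change and the earlier step is the only guide.

Within the data shown here, for compound 4 the step expected in this assay is a 2.6-fold lower number from compound 3 to compound 4 (0.41 log units; beyond the scatter), set to match the earlier one because a 2.6-fold lower number from compound 2 to compound 1 (0.42 log units; beyond the scatter) is the single precedent and rests on one pair only. The estimate for compound 4 in this assay is 6000 nM, with a range from 3000 nM to 12000 nM.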

Compound 4, concentration for total growth inhibition: 6600 nM
Compound 4: the middle estimate sits 1.1-fold (0.04 log units) below what was measured; the measured number falls inside the stated range.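

In this assay, chloro in place of hydrogen on an aromatic carbon, here between two ring nitrogen atoms, gives a 2.3-fold lower number from compound 3 to compound 4 (0.37 log units; beyond the scatter), and the step keeps much the same size on the second core: the same change on two cores in this assay, a 2.6-fold lower number (0.42 log units; beyond the scatter) from compound 2 to compound 1 and a 2.3-fold lower number (0.37 log units; beyond the scatter) from compound 3 to compound 4, 1.1-fold (0.05 log units) apart, within the scatter of two such steps. On these two cores, then, the change lowers the number by a like amount, and the two cores do not separate in their response to it. This does not show that the step would hold on a further core or in another assay: it rests on two pairs in a single cell line at one stated time, and it says nothing about why the number falls.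

Still open, on these data alone, is whether an amine or a methoxy group at the same place would also move the number in the same way on both cores. Also open, as far as these compounds go, is how a longer chain in place of the chloro would behave there, and whether any such replacement would keep the two cores in step.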